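Phenyl-to-pyridyl swap and a methylated pyridin-2-yl

The source may report more compounds than this note shows. Statements on the series, on what has been measured and on what is new or still open speak of the compounds shown alone.

Measured so far:
compound 1 `O=c1cc(CN(c2ccccc2)c2cccc(Cl)c2)c2ccc(F)c(F)c2[nH]1` in an assay on HEK293 cells for inhibition of Nitric oxide synthase, inducible (Homo sapiens), read by fluorescence; on this read-out higher numbers stand for weaker inhibition and lower numbers for stronger inhibition: 1500 nM
compound 2 `O=c1cc(CN(c2cccnc2)c2cccc(Cl)c2)c2ccc(F)c(F)c2[nH]1` in this assay: 77 nM
compound 3 `O=c1cc(CN(Cc2ccc(Cl)cc2)c2cnccn2)c2ccc(F)c(F)c2[nH]1` in this assay: 77 nM

Compound 2 stands level with compound 3 at the digits shown, the two lowest numbers of the three; compound 1 sits furthest away, with a 19-fold lower number from compound 1 to compound 2 (1.29 log units; beyond the scatter).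

Compound 4 `Cc1cccnc1N(Cc1cc(=O)[nH]c2c(F)c(F)ccc12)c1cccc(Cl)c1` differs from compound 2 by 3-methylpyridin-2-yl in place of pyridin-3-yl on a nitrogen on an aromatic ring. Among the compounds with values here, no measured step covers this change: the only step known concerns pyridin-3-yl against phenyl, not a shift of the ring nitrogen together with an added methyl. The step of a 19-fold lower number from compound 1 to compound 2 (1.29 log units; beyond the scatter) shows that this nitrogen substituent matters a great deal in this assay, so a change beyond the scatter is possible in either direction. Within the data shown here, with no direct precedent, compound 4 is expected near or somewhat weaker than compound 2, estimated as a 2.6-fold higher number from compound 2 to compound 4 (0.41 log units; beyond the scatter), giving 200 nM with a range of 50 nM to 800 nM.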

Compound 4, half-maximal inhibitory concentration: 350 nM
The estimate for compound 4 lay 1.8-fold (0.24 log units) below the measured number, within the range that was stated.
By their numbers in this assay, from the lowest: compounds 2 and 3 (each within the scatter of the next); then compound 4; then compound 1.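

In this assay, 3-methylpyridin-2-yl on this nitrogen gives up part of the gain seen with pyridin-3-yl, with a 4.5-fold higher number from compound 2 to compound 4 (0.66 log units; beyond the scatter), yet keeps an advantage over phenyl, with a 4.3-fold lower number from compound 1 to compound 4 (0.63 log units; beyond the scatter). The size of the gain over phenyl therefore depends on which of these two rings enters, and a ring with one hetero atom does not fix it alone. No measurement available here bears on the reason for this difference.

The ring nitrogen shift and the added methyl change together, so their separate contributions cannot be read. From the compounds shown here alone, how plain pyridin-2-yl, or a pyridin-3-yl ring carrying an amine, would compare remains open.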